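Benzyloxy for Bromo on a Shared Dichalcone Core

The compounds below may be only part of what the source reports. "The series", "measured", "known", "first", "only" and "open" are said of these compounds alone.

In a functional assay on MCF7 cells (Homo sapiens) for cytotoxicity, read by MTT assay, with a stated time of 24 h (a higher number here means a weaker inhibitor, a lower number a stronger inhibitor), compound 1 `Cc1cc(O)c(C(=O)/C=C/c2ccc(OCc3ccccc3)cc2)c(-c2ccccc2)c1C(=O)/C=C/c1ccc(OCc2ccccc2)cc1` gives 10000 nM. Compound 2 `Cc1cc(O)c(C(=O)/C=C/c2ccc(Cl)cc2)c(-c2ccc(Br)cc2)c1C(=O)/C=C/c1ccc(Cl)cc1` gives 20000 nM. Compound 3 `Cc1cc(O)c(C(=O)/C=C/c2ccc(OCc3ccccc3)cc2)c(-c2ccc(Br)cc2)c1C(=O)/C=C/c1ccc(OCc2ccccc2)cc1` gives 20000 nM.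

Compound 3 stands level with compound 2 at the digits shown, the pair forming the highest of the three numbers, with compound 1 the furthest from it; even that gap, a 2.0-fold higher number from compound 1 to compound 3 (0.30 log units; within the scatter), lies within the scatter. Compound 4 `Cc1cc(O)c(C(=O)/C=C/c2ccc(OCc3ccccc3)cc2)c(-c2ccc(OCc3ccccc3)cc2)c1C(=O)/C=C/c1ccc(OCc2ccccc2)cc1` differs from compound 3 by benzyloxy in place of bromo on an aromatic carbon. Among the compounds with values here, the only measured step at this position is the one from hydrogen to bromo, and it did not move the number beyond the scatter; nothing here speaks to benzyloxy at that place. Compound 4 is therefore expected to stay at the level of compound 3 in this assay, a 1.3-fold lower number from compound 3 to compound 4 (0.12 log units; within the scatter). The estimate for compound 4 is 15000 nM, within 5000 nM to 45000 nM.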

Compound 4, half-maximal inhibitory concentration: 26000 nM
Compound 4: middle estimate off by 1.7-fold (0.24 log units), on the low side; low and high end bracket the measured number.
By their numbers in this assay, from the lowest: compounds 1, 2, 3 and 4 (each within the scatter of the next, the first and the last beyond it).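

In this assay, the change a 1.3-fold higher number from compound 3 to compound 4 (0.11 log units; within the scatter) stays within the scatter, so benzyloxy, with its added aromatic ring, reads the same as bromo at this position. Measured against hydrogen, the same group gives a 2.6-fold higher number from compound 1 to compound 4 (0.41 log units; beyond the scatter), a modest step and the first at this position to pass beyond the scatter. Nothing available explains this step. From the compounds shown here alone, it remains open whether an amine or a carboxylic acid at this position would move the number in either direction, and whether the step from hydrogen would hold on a core carrying the chloro groups of compound 2.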